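Extending a Chain Substituent on a Shared Core

This account rests on a few compounds, and the source may have more. Where it says the series, first, only, none or still open, it means among the compounds named here.

Of the compounds shown here, two that share one core have been measured in a functional assay on Hep 3B2 cells (Homo sapiens) for cytotoxicity, read by MTT assay, with a stated time of 72 h; a lower number here means a stronger inhibitor, a higher number a weaker inhibitor. Compound 1 `COc1cc(/C=C/C(=O)N2CCC=C(Br)C2=O)cc(OC)c1OC` in this assay gives 8090 nM. Compound 2 `CC/C(=C\c1cc(OC)c(OC)c(OC)c1)C(=O)N1CCC=C(Br)C1=O` in this assay gives 8120 nM. These two numbers are indistinguishable: they sit within the usual scatter of repeated measurements, so neither compound can be called the stronger, and the pair shows only that both act at a similar, modest level. Compound 3 `CCC/C(=C\c1cc(OC)c(OC)c(OC)c1)C(=O)N1CCC=C(Br)C1=O` has not yet been measured. Relative to compound 2 it differs in a single way: methyl in place of hydrogen on a saturated chain carbon, two bonds along the chain from a double-bonded chain carbon. The same difference, cut one bond further out, reads ethyl to propyl. No measured pair in this set shows what such a change does, so there is no step to lean on, and the data give no reason to expect the number to move in either direction. The expected step, a 1.0-fold lower number from compound 2 to compound 3 (0.01 log units; within the scatter), is therefore no larger than the scatter. The estimate for compound 3 is 8000 nM, with a likely range from 3500 nM to 18000 nM.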

Compound 3, half-maximal inhibitory concentration: 5540 nM
The estimate for compound 3 lay 1.4-fold (0.16 log units) above the measured number; the measured number falls inside the stated range.
By their numbers in this assay, from the lowest: compounds 3, 1 and 2 (each within the scatter of the next).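

In this assay, for the compounds shown here, the change from ethyl to propyl, which places methyl in place of hydrogen on a saturated chain carbon, two bonds along the chain from a double-bonded chain carbon, gives a 1.5-fold lower number from compound 2 to compound 3 (0.17 log units; within the scatter) and is the first step that can be read at this position. The earlier compounds shown here offered no step of any kind, whereas this one shows that the chain can carry this added methyl without the number moving beyond the usual scatter of repeated measurements. Nothing measured here bears on why the number sits where it does, and no separate data on the compounds accompany this step.

From the compounds shown here alone, what the chain would tolerate beyond propyl remains open, since a butyl or longer chain, a branched isopropyl group, or a chain ending in an amine or a carboxylic acid might leave the number where it is or might move it clearly. A single step within the scatter also cannot show whether chain length has any real bearing on the number in this assay at all, so only further changes at this same position could settle that question.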